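Methyl to fluoro on the sulfonyl aryl of compound 2

The source may hold more compounds than are shown below. What is called first, only, known or untested is meant among the compounds shown, and "the series" means these compounds.

Measured so far in a functional assay for inhibition of Voltage-dependent N-type calcium channel subunit alpha-1B (Homo sapiens), tested at 10 uM; on this read-out higher numbers stand for more inhibition at the one concentration tested (going by the name of the read-out) and lower numbers for less inhibition:
compound 1 `O=C(CC1c2ccccc2N=C(N2CCCCC2)N1c1ccccc1)NCc1ccccc1` gives 12%;
compound 2 `Cc1ccc(S(=O)(=O)Nc2ccc(CNC(=O)CC3c4ccccc4N=C(N4CCCCC4)N3c3ccccc3)cc2)cc1` gives 38.7%.

Among the measured compounds shown here, compound 2 holds the higher of the two numbers in this assay, the only measured step being a number 26.7 percentage points higher from compound 1 to compound 2 (beyond the scatter). Compound 3 `O=C(CC1c2ccccc2N=C(N2CCCCC2)N1c1ccccc1)NCc1ccc(NS(=O)(=O)c2ccc(F)cc2)cc1` differs from compound 2 by fluoro in place of methyl on an aromatic carbon. For the measured compounds named here, no measured step touches this position, so the one step seen says nothing directly about it. Compound 3 is therefore expected to stay near compound 2, with a number 0.7 percentage points lower from compound 2 to compound 3 (within the scatter) not beyond the scatter. Compound 3 is estimated at 38% in this assay, within 24% to 52%.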

Compound 3, a percentage reported as inhibition, at one concentration (the size of the read-out at that concentration, not a potency): 50.8%
The estimate for compound 3 lay 12.8 percentage points below the measured number, and the stated range covers the measured number.
By their numbers in this assay, from the lowest: compound 1; then compound 2; then compound 3.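

In this assay, this position responds to a one-atom change: fluoro in place of methyl gives a number 12.1 percentage points higher from compound 2 to compound 3 (beyond the scatter) on the sulfonyl aryl. Installed in place of hydrogen, ((4-fluorophenyl)sulfonyl)amino gives a number 38.8 percentage points higher from compound 1 to compound 3 (beyond the scatter) and is the best group of the three compounds at this single concentration. No measurement available here bears on the reason for this difference.

Going by these compounds, whether chloro or methoxy on the same aromatic carbon would match compound 3 remains open. So does whether a carboxylic acid or an amine there would retain the inhibition.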